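The compounds below may be only part of what the source reports. "The series", "measured", "known", "first", "only" and "open" are said of these compounds alone.

Series against an assay on isolated protein (Cricetulus griseus) for inhibition of aldehyde dehydrogenase, mitochondrial (Homo sapiens); on this read-out lower numbers stand for stronger inhibition and higher numbers for weaker inhibition:

Compound 1 `O=C(O)CCCCCCOc1ccc2c(=O)c(-c3ccc(O)cc3)coc2c1`: 9 nM
Compound 2 `O=c1c(-c2ccc(O)cc2)coc2cc(OCCC3OCCCO3)ccc12`: 400 nM
Compound 3 `C=CCOc1ccc2c(=O)c(-c3ccc(O)cc3)coc2c1`: 800 nM

Compound 3 gives the highest number of the three in this assay. Its nearest neighbour is compound 2, and the gap a 2.0-fold higher number from compound 2 to compound 3 (0.30 log units; within the scatter) is within the scatter, so the two cannot be ordered. The far neighbour is compound 1, and the gap an 89-fold higher number from compound 1 to compound 3 (1.95 log units; beyond the scatter) is large; likewise a 44-fold higher number from compound 1 to compound 2 (1.65 log units; beyond the scatter) is large.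

Compound 4 `O=c1c(-c2ccc(O)cc2)coc2cc(OCCCCBr)ccc12` is not yet measured. It differs from compound 3 in one place: 3-bromopropyl in place of vinyl on a saturated chain carbon bound to an oxygen on an aromatic ring.

Within the data shown here, two measured steps bear on the change. an 89-fold higher number from compound 1 to compound 3 (1.95 log units; beyond the scatter) shows that a longer substituent on this oxygen can go with a much lower number, but compound 1 carries a carboxy group that compound 4 lacks. a 2.0-fold higher number from compound 2 to compound 3 (0.30 log units; within the scatter) shows that another longer substituent without a carboxy group stays within the scatter of compound 3. The change to 3-bromopropyl resembles the second case more than the first. A step no larger than the scatter, or a small lowering at most, is therefore expected.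

Compound 4 is estimated at 400 nM, with a range of 100 nM to 1500 nM, which means an expected step of a 2.0-fold lower number from compound 3 to compound 4 (0.30 log units; within the scatter).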

Compound 4, half-maximal inhibitory concentration: 270 nM
Compound 4: the middle estimate sits 1.5-fold (0.17 log units) above what was measured, and the stated range covers the measured number.
By their numbers in this assay, from the lowest: compound 1; then compounds 4, 2 and 3 (each within the scatter of the next, the first and the last beyond it).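

In this assay, 3-bromopropyl in place of vinyl gives a 3.0-fold lower number from compound 3 to compound 4 (0.47 log units; beyond the scatter) as a modest step, so a substituent without a carboxy group on this saturated chain carbon can move the number beyond the scatter, which the within-scatter step between compound 2 and compound 3 did not show. The bromo-ended chain of compound 4 and the ring-ended chain of compound 2 cannot be ordered, with a 1.5-fold lower number from compound 2 to compound 4 (0.17 log units; within the scatter) lying within the scatter, so compound 4 does not separate from compound 2 even though it separates from compound 3. The gap to the carboxy-bearing chain stays large, at a 30-fold higher number from compound 1 to compound 4 (1.48 log units; beyond the scatter) in this series, and a bromo end in place of 2-carboxyethyl on the chain does not close it.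

Compound 1 differs from the others in both the carboxylic acid and the longer chain, and a methyl ester or a plain hexyl chain on the same oxygen would be needed to separate those two features. Nothing among the data given here explains any of these steps.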